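The source may report more compounds than this note shows. Statements on the series, on what has been measured and on what is new or still open speak of the compounds shown alone.

Measured in an ADME assay on HEK293 cells (Homo sapiens) for cytotoxicity, read by resazurin assay, with a stated time of 48 h; a lower number here means that less compound is tolerated, a higher number that more compound is tolerated:

Compound 1 `O=S(=O)(Nc1ccc2oc(-c3ccccc3)nc2c1)c1cccc(F)c1`: 68000 nM
Compound 2 `O=S(=O)(Nc1ccc2oc(-c3ccccc3)nc2c1)c1cccc(Cl)c1`: 70000 nM
Compound 3 `O=S(=O)(Nc1ccc2oc(-c3ccccc3)nc2c1)c1ccc(O)cc1`: > 100000 nM, a limit of the assay and not a number

Compound 3 thus stands only at a limit, with no exact value. Compound 4 `CS(=O)(=O)Nc1ccc2oc(-c3ccccc3)nc2c1` has methyl in place of 4-hydroxyphenyl on a sulfonyl sulfur. The nearest evidence is two changes at that same place, an at least 1.4-fold higher number from compound 1 to compound 3 (0.16 log units; that floor lies within the scatter) and an at least 1.4-fold higher number from compound 2 to compound 3 (0.15 log units; that floor lies within the scatter), and both are floors within the scatter. The step of a 1.0-fold higher number from compound 1 to compound 2 (0.01 log units; within the scatter) also stays within the scatter. No measured change at this place therefore exceeds the scatter, and the expected step is a number no higher from compound 3 to compound 4 (the limit leaves the size open), with no shift beyond the scatter expected. For compound 4 the estimated value is 100000 nM, with an expected range of 45000 nM to 200000 nM.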

Compound 4, half-maximal cytotoxic concentration: > 100000 nM
Compound 4 was reported as a limit; the forecaster's own chance of this, stated with the estimate: 55%; the middle value sits exactly at the limit.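

In this assay, compound 4 stands at > 100000 nM, a limit of the assay and not a number, so methyl on the sulfonyl sulfur, with no ring, gives a result of the same kind as the 4-hydroxyphenyl group. The readable steps are an at least 1.4-fold higher number from compound 2 to compound 4 (0.15 log units; that floor lies within the scatter) and an at least 1.4-fold higher number from compound 1 to compound 4 (0.16 log units; that floor lies within the scatter), so no shift beyond the scatter can be read at this position. The step between compound 3 and compound 4 cannot be read because both sit at the same limit: the limit of > 100000 nM in this assay, at which 2 of the 4 values shown sit.

On these data alone, how far compound 3 and compound 4 lie past that limit stays open. So does whether an amine, a carboxylic acid or a longer chain on the sulfonyl sulfur would give a measurable value.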